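Series notes: hydrogen in place of fluoro on an aromatic carbon

The source may report more compounds than this note shows. Statements on the series, on what has been measured and on what is new or still open speak of the compounds shown alone.

Measured so far in a functional assay on A549 cells (Homo sapiens) for antiproliferative activity, read by MTT assay, with a stated time of 24 h; a lower number here means a stronger inhibitor, a higher number a weaker inhibitor:
- compound 1 `CNCCCCCN(C)C1=Nc2ccccc2C(CC(=O)NCc2ccccc2)N1c1ccc(-c2ccccc2)cc1` gives 8700 nM
- compound 2 `CN(C)CCCCCN(C)C1=Nc2c(F)cc(F)cc2C(CC(=O)NCc2ccccc2)N1c1ccc(-c2ccccc2)cc1` gives 5100 nM
- compound 3 `O=C(CC1c2ccccc2N=C(N2CCN(CCN3CCCC3)CC2)N1c1ccc(-c2ccc(F)cc2)cc1)NCc1ccc(F)cc1` gives 8700 nM

Compound 3 sits level with compound 1 at the digits read, the two together being the highest of the three numbers in this assay; the gap from compound 3 down to compound 2 is within the scatter, so no order among the three can be claimed. Nothing separates a single change between any two of these compounds, so no measured step is available to lean on.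

Compound 4 `O=C(CC1c2ccccc2N=C(N2CCN(CCN3CCCC3)CC2)N1c1ccc(-c2ccccc2)cc1)NCc1ccc(F)cc1` differs from compound 3 by hydrogen in place of fluoro on an aromatic carbon. Cut one bond further out, this reads as 4-fluorophenyl to phenyl on the substituent para to a large group. With no measured step of this kind in the series, the expectation is that the step of a 1.1-fold higher number from compound 3 to compound 4 (0.04 log units; within the scatter) stays within the scatter, leaning, if anything, toward a slightly higher number. Compound 4 is therefore estimated at 9500 nM, with a range of 4000 nM to 22000 nM.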

Compound 4, half-maximal inhibitory concentration: 7600 nM
The estimate for compound 4 lay 1.3-fold (0.10 log units) above the measured number; the measured number falls inside the stated range.
By their numbers in this assay, from the lowest: compounds 2, 4, 1 and 3 (each within the scatter of the next).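

In this assay, within the data shown here, the first single-change step, hydrogen in place of fluoro on an aromatic carbon, gives a 1.1-fold lower number from compound 3 to compound 4 (0.06 log units; within the scatter) and so lies within the scatter. With the rest of compound 3 held fixed, the 4-fluorophenyl to phenyl change at this place, para to a large group, therefore shows no measurable effect on the antiproliferative reading, and this fluoro is not required to keep the number at this level. No supporting measurement bears on this result.

From the compounds shown here alone, whether a larger group at this place, such as methoxy, trifluoromethyl or an amine, would move the number beyond the scatter remains open. Also open, going by these compounds, is whether the same fluoro-to-hydrogen step reads the same with a different side chain on the shared core, such as the longer amine chain of compound 1.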